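A few compounds are considered here, and "the series" means these few. Any claim that something is new, unique, unknown or untested is made for them only; others in the source may bear on it.

Compound 1, with the structure `O=C(/C=C/c1ccc2c(c1)B(O)OC2)c1ccc(Br)cc1`, was tested in an ADME assay on L929 cells (Mus musculus) for cytotoxicity, read by resazurin assay, with a stated time of 72 h (on this read-out lower numbers stand for stronger inhibition and higher numbers for weaker inhibition), where its value of > 10 ug/mL is only a limit of the assay and not a number. Two close relatives give numbers in this assay: compound 2 `Cc1cccc(C(=O)/C=C/c2ccc3c(c2)B(O)OC3)c1` gives 8.56 ug/mL, and compound 3 `Nc1cccc(C(=O)/C=C/c2ccc3c(c2)B(O)OC3)c1` gives 10 ug/mL. The step of an at least 1.1-fold lower number from compound 1 to compound 2 (0.06 log units; that floor lies within the scatter) and the step of a number no higher from compound 1 to compound 3 (the limit leaves the size open) both swap the whole 4-bromophenyl group on the carbonyl carbon, and neither reveals a clear change in the read-out; the step of a 1.2-fold higher number from compound 2 to compound 3 (0.07 log units; within the scatter) likewise stays small.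

Compound 4 `COc1ccc(C(=O)/C=C/c2ccc3c(c2)B(O)OC3)cc1` is not yet measured in this assay. It differs from compound 1 by methoxy in place of bromo on an aromatic carbon. This is a smaller swap than the two measured ones, which both left the read-out near the limit of compound 1 (the limit of > 10 ug/mL in this assay, at which 1 of the 3 values shown sits). No step beyond the scatter is therefore expected, and the result may again be a limit. Compound 4 is expected to give 10 ug/mL, with a range from 5 ug/mL to 20 ug/mL. This estimate means an expected step of a number no higher from compound 1 to compound 4 (the limit leaves the size open).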

Compound 4, half-maximal inhibitory concentration: > 10 ug/mL
Compound 4 was reported as a limit (the forecaster's own chance of this, stated with the estimate: 50%); the middle value sits exactly at the limit.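

Compound 1 and compound 4 are both reported only as limits, not numbers, so swapping bromo for methoxy gives no readable step in this assay: the limit of > 10 ug/mL in this assay, at which 2 of the 4 values shown sit.

The compounds shown leave open whether these two compounds differ at all on this read-out, and by how much.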